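Ring size on the shared core: seven- to eight-membered

A few compounds are considered here, and "the series" means these few. Any claim that something is new, unique, unknown or untested is made for them only; others in the source may bear on it.

Compound 1 `CC(C(=O)NCc1ccc(C(F)(F)F)nc1N1CCCC1)c1ccc(NS(C)(=O)=O)c(F)c1` gives 0.6 nM in a functional assay on CHO-K1 cells for antagonist activity at transient receptor potential cation channel subfamily V member 1 (Homo sapiens), read by FLIPR; a higher number here means a weaker inhibitor, a lower number a stronger inhibitor. Compound 2 `CC(C(=O)NCc1ccc(C(F)(F)F)nc1N1CCC(=O)CC1)c1ccc(NS(C)(=O)=O)c(F)c1` gives 91 nM, and compound 3 `CC(C(=O)NCc1ccc(C(F)(F)F)nc1N1CCCCCC1)c1ccc(NS(C)(=O)=O)c(F)c1` gives 0.8 nM in this assay; compound 3 thus stands second highest of the three numbers, nearest to compound 1 and furthest from compound 2. Compound 4 `CC(C(=O)NCc1ccc(C(F)(F)F)nc1N1CCCCCCC1)c1ccc(NS(C)(=O)=O)c(F)c1` is not yet measured. The change is a group of 8 heavy atoms (7 carbon, 1 nitrogen; one eight-membered non-aromatic ring with 1 hetero atom) in place of a group of 7 heavy atoms (6 carbon, 1 nitrogen; one seven-membered non-aromatic ring with 1 hetero atom), on an aromatic carbon. The step from compound 1 to compound 3 is the one earlier ring enlargement and was small, a 1.3-fold higher number from compound 1 to compound 3 (0.12 log units; within the scatter), whereas the large step of a 150-fold higher number from compound 1 to compound 2 (2.18 log units; beyond the scatter) turns on a carbonyl rather than ring size and bears little here. For compound 4 a step of small size is therefore expected in this assay, a 1.3-fold higher number from compound 3 to compound 4 (0.10 log units; within the scatter), none beyond the scatter. Compound 4 is estimated at 1 nM, with a range of 0.3 nM to 4 nM.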

Compound 4, inhibition constant: 0.7 nM
Compound 4: middle estimate off by 1.4-fold (0.15 log units), on the high side; low and high end bracket the measured number.
By their numbers in this assay, from the lowest: compounds 1, 4 and 3 (each within the scatter of the next); then compound 2.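

Within the data shown here, the eight-membered non-aromatic ring is indistinguishable from the seven-membered one in this assay (a 1.1-fold lower number from compound 3 to compound 4 (0.06 log units; within the scatter)) and from the five-membered ring of compound 1 (a 1.2-fold higher number from compound 1 to compound 4 (0.07 log units; within the scatter)), so the flat range extends one ring size further than the earlier compounds showed. The 4-oxopiperidin-1-yl compound remains the only outlier (a 130-fold lower number from compound 2 to compound 4 (2.11 log units; beyond the scatter)). Nothing available explains this flat range.

Open, going by these compounds, is whether a hydroxyl or an amine on these larger rings would behave like the carbonyl of compound 2. Also open, on these data alone, is whether an open-chain diethylamino group would match the cyclic amines.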